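Aryl Swap at the Shared Core: Phenyl to Fluoropyridyl

The source may report more compounds than this note shows. Statements on the series, on what has been measured and on what is new or still open speak of the compounds shown alone.

Measured so far:
compound 1 `O=C(Nc1cccc(C(F)(F)F)c1)c1cc(=O)[nH]c2cc(Br)ccc12` in a functional assay on KYSE-410 cells (Homo sapiens) for antiproliferative activity, read by MTT assay, with a stated time of 72 h (on this read-out higher numbers stand for weaker inhibition and lower numbers for stronger inhibition), gives > 20000 nM 
compound 2 `O=C(Nc1cccc(F)c1)c1cc(=O)[nH]c2cc(-c3ccc(F)cc3)ccc12` in this assay gives 10300 nM 

The value for compound 1 is a limit of the assay, not a number. Compound 2 holds the only number shown in this assay. Compound 3 `O=C(Nc1cccc(F)c1)c1cc(=O)[nH]c2cc(-c3ccc(F)nc3)ccc12` differs from compound 2 by the change (6-fluoropyridin-3-yl in place of 4-fluorophenyl on an aromatic carbon). Among the measured compounds shown here, no measured pair shows what this kind of change does, so compound 3 is expected to stay close to compound 2, with a step of a 1.4-fold higher number from compound 2 to compound 3 (0.13 log units; within the scatter), no larger than the usual scatter. Compound 3 is estimated at 14000 nM, in the range 5000 nM to 40000 nM.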

Compound 3, half-maximal inhibitory concentration: > 20000 nM
Compound 3 ended at the assay's limit; the forecaster's own chance of this, stated with the estimate: 30%; middle value at least 1.4-fold (0.15 log units) away from the limit.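

In this assay compound 3 gives > 20000 nM, which is a limit of the assay and not a number. Among the compounds shown here, the exchange of 4-fluorophenyl for 6-fluoropyridin-3-yl gives the only step readable at this position, an at least 1.9-fold higher number from compound 2 to compound 3 (0.28 log units; that floor lies within the scatter), so the ring nitrogen brings no lower number here. Only a floor can be read for this step, and its full size stays unknown: the limit of > 20000 nM in this assay, at which 2 of the 3 values shown sit.

From the compounds shown here alone, whether an amine, a carboxylic acid or a morpholine in place of the 6-fluoropyridin-3-yl would give a lower number than compound 2 stays open.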